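Thiosemicarbazone series on a terpene core: growth inhibition notes

This account rests on a few compounds, and the source may have more. Where it says the series, first, only, none or still open, it means among the compounds named here.

Compound 1, `CC1=CC[C@H](C(C)(C)N=C=S)CC1`, is the starting point of the series; in a functional assay on NCI/ADR-RES cells (Homo sapiens) for inhibition, read by sulforhodamine B assay, with a stated time of 48 h (on this read-out lower numbers stand for stronger inhibition of growth and higher numbers for weaker inhibition of growth), compound 1 reaches only the limit > 100000 nM. Among the compounds with values here, compound 2, `COc1ccc(/C=N/NC(=S)NC(C)(C)[C@H]2CC=C(C)CC2)cc1`, gives 43800 nM in this assay, the only number recorded so far. The remaining entry, that of compound 1, is a limit, namely (the limit of > 100000 nM in this assay, at which 1 of the 2 values shown sits). Compound 3, `CC1=CC[C@H](C(C)(C)NC(=S)N/N=C/c2ccccc2O)CC1`, differs from compound 2 by 2-hydroxyphenyl in place of 4-methoxyphenyl on a carbon with a double bond to nitrogen. Within the data shown here, no measured step shows how this exchange acts; the expected step of a 1.1-fold lower number from compound 2 to compound 3 (0.04 log units; within the scatter) is none beyond the usual scatter. Compound 3 is therefore estimated at 40000 nM, within 12000 nM to 100000 nM.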

Compound 3, concentration for 50% growth inhibition: 3700 nM
The estimate for compound 3 lay 11-fold (1.03 log units) above the measured number; measured number outside the range, below it.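

In this assay, the group on the carbon with a double bond to nitrogen proves to be a place where one exchange moves the read-out: 2-hydroxyphenyl in place of 4-methoxyphenyl gives a 12-fold lower number from compound 2 to compound 3 (1.07 log units; beyond the scatter). Compound 2 alone could not show that this position responds to change. Nothing shown gives a cause for this step. As far as these compounds go, it stays open whether the step belongs to the hydroxy group itself or to where it sits on the phenyl ring. From the compounds shown here alone, how an amine or a carboxylic acid on that ring would read in this assay also stays open.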